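Replacing the amide of compound 2 with a secondary amine

This account rests on a few compounds, and the source may have more. Where it says the series, first, only, none or still open, it means among the compounds named here.

Measured in a functional assay on SF-268 cells (Homo sapiens) for inhibition, read by sulforhodamine B assay, with a stated time of 48 h (a lower number here means a stronger inhibitor of growth, a higher number a weaker inhibitor of growth), so far:
- compound 1 `CCCCCCCCCCCC[C@@H](O)[C@H]1CC[C@H]([C@H](O)CCCCCCCCCCNC(=O)c2ccnn2C)O1` gives 100000 nM
- compound 2 `CCCCCCCCCCCC[C@@H](O)[C@H]1CC[C@H]([C@H](O)CCCCCCCCCCN(C)C(=O)c2ccnn2C)O1` gives 15100 nM

Compound 2 is the stronger growth inhibitor of this pair. Compound 3 `CCCCCCCCCCCC[C@@H](O)[C@H]1CC[C@H]([C@H](O)CCCCCCCCCCNCc2ccnn2C)O1` differs from it as follows: ((1-methyl-1H-pyrazol-5-yl)methyl)amino in place of methyl((1-methyl-1H-pyrazol-5-yl)carbonyl)amino on a saturated chain carbon, ten or more bonds along the chain from an oxygen on a saturated carbon and a saturated ring carbon. Among the compounds with values here, the only measured step is a 6.6-fold lower number from compound 1 to compound 2 (0.82 log units; beyond the scatter) with methyl in place of hydrogen on an amide-type nitrogen. Within the data shown here, compound 3 also lacks that methyl, but no measured compound shows the carbonyl removed, so this step is only a partial guide. No change beyond the scatter is therefore expected, and the estimated step is a 1.0-fold lower number from compound 2 to compound 3 (0.00 log units; within the scatter) with wide uncertainty. Compound 3 is estimated at 15000 nM in this assay with 4000 nM to 60000 nM as the expected range.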

Compound 3, concentration for 50% growth inhibition: 3630 nM
The estimate for compound 3 lay 4.1-fold (0.62 log units) above the measured number; measured number outside the range, below it.
By their numbers in this assay, from the lowest: compound 3; then compound 2; then compound 1.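

In this assay, the amine linkage gives the strongest growth inhibition of the three compounds. (1-methyl-1H-pyrazol-5-yl)methyl in place of (1-methyl-1H-pyrazol-5-yl)carbonyl on the nitrogen gives a 28-fold lower number from compound 1 to compound 3 (1.44 log units; beyond the scatter), a large step, whereas methyl on the amide nitrogen gave only a modest one. The secondary amine also outperforms the methylated amide, with a 4.2-fold lower number from compound 2 to compound 3 (0.62 log units; beyond the scatter). Nothing shown here gives a reason for these gains.

Still open, on these data alone, is whether a tertiary amine carrying a methyl on this nitrogen would go further. As far as these compounds go, it is equally open whether a sulfonamide at this position would keep the gain.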